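A few compounds are considered here, and "the series" means these few. Any claim that something is new, unique, unknown or untested is made for them only; others in the source may bear on it.

Among the compounds with values here, in a functional assay on the whole organism with Rattus norvegicus as the target (a lower number here means that less compound is needed, a higher number that more compound is needed for the effect), compound 3 `CCOC(=O)C(=O)Nc1cccc(C(=O)OC)c1C#N` gives 0.8 mg/kg, the middle of the three numbers so far. Compound 2 `CCCCNc1cccc(NC(=O)C(=O)OCC)c1C#N` stands lower at 0.3 mg/kg, and compound 1 `CCOC(=O)C(=O)Nc1cccc(OC)c1C#N` stands far higher at 55.5 mg/kg. Compound 4 `CCOC(=O)C(=O)Nc1cccc(F)c1C#N` has fluoro in place of methoxycarbonyl on an aromatic carbon, ortho to a cyano group: fluoro in place of methoxycarbonyl on an aromatic carbon.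

All three measured steps change this same substituent. Methoxycarbonyl in place of methoxy gave a 69-fold lower number from compound 1 to compound 3 (1.84 log units; beyond the scatter), and butylamino in place of methoxy gave a 190-fold lower number from compound 1 to compound 2 (2.27 log units; beyond the scatter). Methoxycarbonyl in place of butylamino gave only a 2.7-fold higher number from compound 2 to compound 3 (0.43 log units; beyond the scatter). Two of the three substituents therefore give low numbers, and the methoxy of compound 1 goes against them. Within the data shown here, no measured compound carries fluoro, so the direction is uncertain, and a large step remains possible given compound 1 at 55.5 mg/kg.

A modest rise in this assay is expected, estimated as a 3.8-fold higher number from compound 3 to compound 4 (0.57 log units; beyond the scatter). For compound 4 the estimated value is 3 mg/kg, with an expected range of 0.5 mg/kg to 20 mg/kg.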

Compound 4, dose for half-maximal effect: 59 mg/kg
The estimate for compound 4 lay 20-fold (1.29 log units) below the measured number; the measured number lies above the stated range.
By their numbers in this assay, from the lowest: compound 2; then compound 3; then compounds 1 and 4 (each within the scatter of the next).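

In this assay fluoro in place of methoxycarbonyl on this aromatic carbon gives a 74-fold higher number from compound 3 to compound 4 (1.87 log units; beyond the scatter) and fluoro in place of butylamino gives a 200-fold higher number from compound 2 to compound 4 (2.29 log units; beyond the scatter), so a substituent as well as methoxy can give a high number here. Fluoro in place of methoxy gives a 1.1-fold higher number from compound 1 to compound 4 (0.03 log units; within the scatter), so the high number of compound 1 no longer stands alone: the four substituents form a low pair, butylamino and methoxycarbonyl, and a high pair, methoxy and fluoro. Nothing measured here bears on why the substituents divide in this way.

Still open, on these data alone, is whether a primary amine, a carboxylic acid or a chain longer than butylamino at this carbon would join the low pair or the high pair. Also open, as far as these compounds go, is whether the same division holds when the ethyl ester of the shared core gives way to a carboxylic acid.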